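Swapping One Fluoro for Chloro on a Weak Compound

The compounds below may be only part of what the source reports. "The series", "measured", "known", "first", "only" and "open" are said of these compounds alone.

In a functional assay on NCI/ADR-RES cells (Homo sapiens) for inhibition (on this read-out lower numbers stand for stronger inhibition of growth and higher numbers for weaker inhibition of growth), compound 1 (`O=S(=O)(/C=C/c1ccc(Cl)c(Cl)c1)Cc1ccc(Nc2ncnc3ccccc23)cc1`) gives 22000 nM. Compound 2 (`O=S(=O)(/C=C/c1ccc(F)cc1F)Cc1ccc(Nc2ncnc3ccccc23)cc1`) gives > 100000 nM in this assay, and this is a limit of the assay, not a number. Compound 3 (`O=S(=O)(/C=C/c1ccc(F)cc1Cl)Cc1ccc(Nc2ncnc3ccccc23)cc1`) differs from compound 2 at a single place: chloro in place of fluoro on an aromatic carbon. Chloro replaces fluoro on an aromatic carbon, ortho to a large group and meta to a fluoro group, giving 2-chloro-4-fluorophenyl in place of 2,4-difluorophenyl. Among the compounds with values here, only one measured step bears on this change, an at least 4.5-fold higher number from compound 1 to compound 2 (0.65 log units; beyond the scatter), and it is beyond the usual scatter. That step changes more of the ring than the new swap does, so it offers only a rough guide. Compound 1, which carries chloro, gives 22000 nM, so a partial move toward that value is expected. The reading for compound 3 could still remain at the limit seen for compound 2. The expected change is an at least 1.6-fold lower number from compound 2 to compound 3 (0.22 log units; that floor lies within the scatter), towards a lower number and so towards stronger inhibition of growth. For compound 3 the estimated value is 60000 nM, with an expected range of 20000 nM to 100000 nM.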

Compound 3, concentration for 50% growth inhibition: 66000 nM
The estimate for compound 3 lay 1.1-fold (0.04 log units) below the measured number; the range from low to high includes it.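

In this assay, compound 3 gives a measured number, whereas compound 2 does not, so placing chloro instead of fluoro on this aromatic carbon, ortho to a large group, brings the series back within the range the assay can report, with an at least 1.5-fold lower number from compound 2 to compound 3 (0.18 log units; that floor lies within the scatter). As far as these compounds go, the true size of this step stays unknown, and only its floor can be stated, because the value for compound 2 is a limit of the assay and not a number: the limit of > 100000 nM in this assay, at which 1 of the 3 values shown sits. The single chloro does not close the whole gap to the 3,4-dichlorophenyl ring, since the comparison of the two ring patterns gives a 3.0-fold higher number from compound 1 to compound 3 (0.48 log units; beyond the scatter), a modest step towards weaker inhibition of growth.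

What the compounds shown leave open is whether chloro is special on this aromatic carbon, or whether bromo, methyl or methoxy there would give a similar or lower number. They also leave open how each ring position contributes on its own, since compound 1 and compound 3 differ in more than one ring substituent.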